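The source may report more compounds than this note shows. Statements on the series, on what has been measured and on what is new or still open speak of the compounds shown alone.

Of the compounds shown here, two of the shared core have been measured. Compound 1 `C=C1[C@@H](OC(C)=O)C[C@@H]2[C@](C)(CO[Si](C)(C)C(C)(C)C)[C@H](OC(C)=O)CC[C@@]2(C)[C@@H]1C[C@@H](Nc1ccc(OC)cc1)C1=CCOC1=O` carries a (4-methoxyphenyl)amino group on the saturated chain carbon that links the core to the lactone; in a functional assay on HT-29 cells (Homo sapiens) for cytotoxicity, read by sulforhodamine B assay (on this read-out higher numbers stand for weaker inhibition and lower numbers for stronger inhibition), compound 1 gives 5370 nM. Compound 2 `C=C1CC[C@@H]2[C@](C)(CO[Si](C)(C)C(C)(C)C)[C@H](OC(C)=O)CC[C@@]2(C)[C@@H]1C/C=C1/C(=O)OC[C@H]1OC(C)=O` differs from it in several places at once and is not a single-point neighbour; in this assay compound 2 gives 4690 nM. Among the measured compounds shown here, the two values sit within the usual scatter of each other, so the series so far reads as flat, with compound 1 at one end of a narrow pair and no step between measured compounds available to calibrate a change at the amine nitrogen.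

Compound 3 `C=C1[C@@H](OC(C)=O)C[C@@H]2[C@](C)(CO[Si](C)(C)C(C)(C)C)[C@H](OC(C)=O)CC[C@@]2(C)[C@@H]1C[C@@H](Nc1cccc2ccccc12)C1=CCOC1=O` is the next member: naphthalen-1-yl in place of 4-methoxyphenyl on an amine nitrogen. For the measured compounds named here, no measured pair shows what exchanging the aryl group on this amine nitrogen does, so no direction is supported by the data. The expected step of a 1.1-fold lower number from compound 1 to compound 3 (0.03 log units; within the scatter) is therefore taken as none beyond the scatter, with the range widened for the lack of precedent. On that basis compound 3 is estimated at 5000 nM, within 1500 nM to 16000 nM.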

Compound 3, half-maximal inhibitory concentration: 15000 nM
The estimate for compound 3 lay 3.0-fold (0.48 log units) below the measured number; the range from low to high includes it.
By their numbers in this assay, from the lowest: compounds 2 and 1 (each within the scatter of the next); then compound 3.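

The exchange of 4-methoxyphenyl for naphthalen-1-yl on the amine nitrogen gives the series its first calibrated step: in this assay, the change reads as a 2.8-fold higher number from compound 1 to compound 3 (0.45 log units; beyond the scatter), so the flat look of the earlier pair does not extend to the aryl group at this position. The step is modest and runs towards weaker inhibition, which shows that the read-out responds to this aryl group while compound 3 still gives a measured number. The change replaces one aromatic ring carrying a methoxy group with two fused aromatic rings and so alters more than one feature at once, and no supporting measurement accounts for the step.

From the compounds shown here alone, it remains open whether the step follows from the loss of the methoxy group or from the second aromatic ring, and a plain phenyl group or a naphthalen-2-yl group on the same amine nitrogen would help to separate the two. Going by these compounds, it is also open how a non-aromatic group on this nitrogen, such as cyclohexyl or a longer alkyl chain, would read against compound 1.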